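Oxolan-3-yl to oxolan-2-yl: expected clearance of compound 4

The source may hold more compounds than are shown below. What is called first, only, known or untested is meant among the compounds shown, and "the series" means these compounds.

In an in vitro ADME assay on microsomes from liver (Homo sapiens) for metabolic stability, read by HPLC (on this read-out higher numbers stand for fast clearance and lower numbers for slow clearance), compound 1 `CC1(C)C[C@H](CN([C@H](CCC(F)(F)F)C(N)=O)S(=O)(=O)c2ccc(Cl)cc2)O1` gives 29 mL/min/kg while compound 2 `NC(=O)[C@@H](CCC(F)(F)F)N(CC1CCOCC1)S(=O)(=O)c1ccc(Cl)cc1` gives 114 mL/min/kg and compound 3 `NC(=O)[C@@H](CCC(F)(F)F)N(C[C@H]1CCOC1)S(=O)(=O)c1ccc(Cl)cc1` gives 83.4 mL/min/kg on the same scale. Compound 3 has its nearest neighbour in a 1.4-fold lower number from compound 2 to compound 3 (0.14 log units; within the scatter) and its furthest in a 2.9-fold higher number from compound 1 to compound 3 (0.46 log units; beyond the scatter) among the measured values.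

The change to compound 4 `NC(=O)[C@@H](CCC(F)(F)F)N(C[C@@H]1CCCO1)S(=O)(=O)c1ccc(Cl)cc1` is oxolan-2-yl in place of oxolan-3-yl on a saturated chain carbon bound to a sulfonamide nitrogen, counted as oxolan-2-yl in place of oxolan-3-yl on a saturated chain carbon bound to a sulfonamide nitrogen with the same atoms joined differently.

For the measured compounds named here, no measured step moves the attachment within one ring, so the expectation rests on analogy. Going by the values given here, the closest case is oxolan-3-yl in place of oxan-4-yl, seen in a 1.4-fold lower number from compound 2 to compound 3 (0.14 log units; within the scatter) as the only step between unsubstituted rings. The larger steps of a 3.9-fold higher number from compound 1 to compound 2 (0.59 log units; beyond the scatter) and a 2.9-fold higher number from compound 1 to compound 3 (0.46 log units; beyond the scatter) both involve 4,4-dimethyloxetan-2-yl, which compound 4 lacks.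

The estimated step is a 1.0-fold lower number from compound 3 to compound 4 (0.02 log units; within the scatter) and no shift beyond the scatter is expected in this assay here. For compound 4 the estimated clearance is 80 mL/min/kg with an expected range from 40 mL/min/kg to 150 mL/min/kg on this reasoning.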

Compound 4, clearance: 210 mL/min/kg
Compound 4: middle estimate off by 2.6-fold (0.42 log units), on the low side; the measured number lies above the stated range.
By their numbers in this assay, from the lowest: compound 1; then compounds 3, 2 and 4 (each within the scatter of the next, the first and the last beyond it).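

In this assay, for the compounds shown here, the attachment point within the oxolane ring matters, with the same atoms joined differently: oxolan-2-yl in place of oxolan-3-yl gives (a 2.5-fold higher number from compound 3 to compound 4 (0.40 log units; beyond the scatter)), a step beyond the scatter, whereas the only earlier step between unsubstituted rings stayed within it. Against the six-membered ring, the new group does not separate (a 1.8-fold higher number from compound 2 to compound 4 (0.27 log units; within the scatter)), so oxolan-2-yl cannot be ranked against oxan-4-yl. The widest gap in the series now belongs to the 4,4-dimethyloxetan-2-yl group (a 7.2-fold higher number from compound 1 to compound 4 (0.86 log units; beyond the scatter)), which keeps compound 1 apart from the other three.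

Nothing available explains why the two oxolane attachment points differ. Also open, from the compounds shown here alone, is whether an amine or a longer chain at this place on a saturated chain carbon bound to a sulfonamide nitrogen would fall nearer compound 1 or compound 4.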